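The source may hold more compounds than are shown below. What is called first, only, known or untested is meant among the compounds shown, and "the series" means these compounds.

Measured in an ADME assay on the whole organism for cytotoxicity, with Artemia salina as the target, with a stated time of 24 h (a higher number here means that more compound is needed for the effect, a lower number that less compound is needed), were three compounds:

- compound 1 `Cc1ccc(S(=O)(=O)NC(=O)Nc2ccccc2C(=O)/C=C/c2ccc(N(C)C)cc2)cc1`: 38.1 ug/mL
- compound 2 `COc1cccc(/C=C/C(=O)c2ccccc2NC(=O)NS(=O)(=O)c2ccc(C)cc2)c1`: 23.2 ug/mL
- compound 3 `Cc1ccc(S(=O)(=O)NC(=O)Nc2ccccc2C(=O)/C=C/c2cccc(Br)c2)cc1`: 4.02 ug/mL

Compound 3 stands lowest of the three in this assay; its nearest neighbour is compound 2, and the gap a 5.8-fold lower number from compound 2 to compound 3 (0.76 log units; beyond the scatter) lies beyond the scatter, while the gap a 9.5-fold lower number from compound 1 to compound 3 (0.98 log units; beyond the scatter) is larger still. Compound 4 `Cc1ccc(S(=O)(=O)NC(=O)Nc2ccccc2C(=O)/C=C/c2ccc[nH]2)cc1` differs from compound 3 in one place: 1H-pyrrol-2-yl in place of 3-bromophenyl on a double-bonded chain carbon bound to a double-bonded chain carbon. Going by the values given here, two measured steps bear on this position. The exchange of the aryl group on the double-bonded chain carbon from compound 1 to compound 2 gave a 1.6-fold lower number from compound 1 to compound 2 (0.22 log units; within the scatter), whereas introducing the bromo in place of methoxy from compound 2 to compound 3 gave a 5.8-fold lower number from compound 2 to compound 3 (0.76 log units; beyond the scatter). Among the compounds with values here, removing the bromine-bearing ring is therefore expected to move the number back up, though no measured step covers a five-membered ring on this chain. Compound 4 is estimated at 20 ug/mL in this assay, with a range from 7 ug/mL to 60 ug/mL, which means an expected step of a 5.0-fold higher number from compound 3 to compound 4 (0.70 log units; beyond the scatter).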

Compound 4, concentration for half-maximal effect: 32.1 ug/mL
The estimate for compound 4 lay 1.6-fold (0.21 log units) below the measured number; the measured number falls inside the stated range.
By their numbers in this assay, from the lowest: compound 3; then compounds 2, 4 and 1 (each within the scatter of the next).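

In this assay the low number of compound 3 did not carry over to a five-membered ring at this place: the change to 1H-pyrrol-2-yl gave an 8.0-fold higher number from compound 3 to compound 4 (0.90 log units; beyond the scatter) and left the 3-bromophenyl group alone at the low end of the four compounds. Set against the other two aryl groups, the same ring gave a 1.4-fold higher number from compound 2 to compound 4 (0.14 log units; within the scatter) and a 1.2-fold lower number from compound 1 to compound 4 (0.07 log units; within the scatter) and so sits with them within the scatter, although it differs from them in ring size and brings a hydrogen-bond donor. Nothing available here accounts for the position of compound 3.

From the compounds shown here alone, whether a chloro or a nitro group on the phenyl ring would give a number like that of compound 3 stays open. So does where an unsubstituted phenyl or a furan-2-yl group would fall at this place.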